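Swapping acetyl for methylsulfonyl on compound 1

The compounds below may be only part of what the source reports. "The series", "measured", "known", "first", "only" and "open" are said of these compounds alone.

Three compounds share one core, a cyclic urea linked through an amide to a benzene ring that carries a small aromatic ring with two nitrogens. Compound 1 `CNC(=O)N1CCCc2ccc(NC(=O)c3cccc(-c4ccn(C(C)=O)n4)c3)cc21` gives 87.6% in a functional assay on MV4-11 cells (Homo sapiens) for antiproliferative activity, with a stated time of 6 days, tested at 6.25 uM; on this read-out lower numbers stand for a weaker effect and higher numbers for a stronger effect at the one concentration tested. Compound 3 `CNC(=O)N1CCCc2ccc(NC(=O)c3ccc(-c4cnn(C(C)=O)c4)cc3)cc21` gives 83.8%, and compound 2 `CNC(=O)N1CCCc2ccc(NC(=O)c3ccc(-c4cnn(S(C)(=O)=O)c4)cc3)cc21` gives 40.2%. Compound 1 stands at the top of these three numbers, yet its gap to compound 3 is within the scatter, so the two are not separable; only compound 2 lies clearly beyond it.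

Compound 4 `CNC(=O)N1CCCc2ccc(NC(=O)c3cccc(-c4ccn(S(C)(=O)=O)n4)c3)cc21` differs from compound 1 in one place: methylsulfonyl in place of acetyl on an aromatic nitrogen. Among the measured compounds shown here, one measured step bears directly on this, in the opposite direction: a number 43.6 percentage points higher from compound 2 to compound 3 (beyond the scatter). Reversing that exchange on compound 1 therefore points to a large drop in this assay. The estimated step is a number 43.6 percentage points lower from compound 1 to compound 4 (beyond the scatter), and compound 4 is expected to give about 44%, within a range from 25% to 65%, because compound 1 starts from 87.6%.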

Compound 4, a percentage reported as inhibition, at one concentration (the size of the read-out at that concentration, not a potency): 37%
The estimate for compound 4 lay 7 percentage points above the measured number; the range from low to high includes it.
By their numbers in this assay, from the lowest: compounds 4 and 2 (each within the scatter of the next); then compounds 3 and 1 (each within the scatter of the next).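

In this assay, methylsulfonyl in place of acetyl on the aromatic nitrogen of the 1-acetyl-1H-pyrazol-3-yl group gives a number 50.6 percentage points lower from compound 1 to compound 4 (beyond the scatter). The earlier compounds shown here showed this exchange on one core only, and it now holds on a second core with much the same size: the same change on two cores in this assay, a number 43.6 percentage points higher (beyond the scatter) from compound 2 to compound 3 and a number 50.6 percentage points higher (beyond the scatter) from compound 4 to compound 1, 7 percentage points apart, within the scatter of two such steps. In both pairs the acetyl compound gives the higher number, and neither pair goes against this.

As far as these compounds go, what a plain methyl group, a longer acyl chain such as propanoyl, or a simple hydrogen would give on that nitrogen remains open. Each number also comes from a single concentration, so these results do not tell how the potencies of the compounds compare.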